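Trimming the silicon group on the triple bond

The source may report more compounds than this note shows. Statements on the series, on what has been measured and on what is new or still open speak of the compounds shown alone.

Measured so far:
compound 1 `CC(C)(C)OC(=O)NCC#Cc1ccc2c(c1)C=C([N+](=O)[O-])C(C(F)(F)F)O2`: 1200 nM
compound 2 `CC[Si](C#Cc1ccc2c(c1)C=C([N+](=O)[O-])C(C(F)(F)F)O2)(CC)CC`: 604 nM

In a functional assay on 1321N1 cells for antagonist activity at P2Y purinoceptor 6 (Homo sapiens), read by fluorescence and calcium flux (a lower number here means a stronger inhibitor, a higher number a weaker inhibitor), compound 2 gives 604 nM, the lowest of the two numbers; compound 1 stands at 1200 nM. For the measured compounds named here, the only known step, a 2.0-fold lower number from compound 1 to compound 2 (0.30 log units; within the scatter), lies within the scatter. Compound 3 `C[Si](C)(C)C#Cc1ccc2c(c1)C=C([N+](=O)[O-])C(C(F)(F)F)O2` carries a group of 4 heavy atoms (3 carbon, 1 silicon; no ring) in place of a group of 7 heavy atoms (6 carbon, 1 silicon; no ring), on a triple-bonded carbon. That step exchanged one substituent on the triple-bonded carbon for another without a change beyond the scatter, so for compound 3 a step of a 1.3-fold higher number from compound 2 to compound 3 (0.12 log units; within the scatter) is expected, essentially none beyond the scatter. Compound 3 is estimated at 800 nM, in the range 300 nM to 2500 nM.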

Compound 3, half-maximal inhibitory concentration: 785 nM
The estimate for compound 3 lay 1.0-fold (0.01 log units) above the measured number; the range from low to high includes it.
By their numbers in this assay, from the lowest: compounds 2, 3 and 1 (each within the scatter of the next).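

In this assay, swapping the group of 7 heavy atoms on the triple-bonded carbon for the smaller silicon group of 4 heavy atoms gives a 1.3-fold higher number from compound 2 to compound 3 (0.11 log units; within the scatter). Replacing the group of 9 heavy atoms with that same small group gives a 1.5-fold lower number from compound 1 to compound 3 (0.18 log units; within the scatter), so all three substituents now read alike at this position, despite their different sizes. Nothing measured here bears on why the number stays so flat.

Still open, from the compounds shown here alone, is whether a plain hydrogen, an amine or a carboxylic acid on this triple-bonded carbon would move the number beyond the scatter.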